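This account rests on a few compounds, and the source may have more. Where it says the series, first, only, none or still open, it means among the compounds named here.

Measured so far in a functional assay on COLO 205 cells (Homo sapiens) for inhibition, read by sulforhodamine B assay, with a stated time of 48 h; a lower number here means that less compound is tolerated, a higher number that more compound is tolerated:
- compound 1 `COc1cc(-c2nn(-c3cccc(NC(=O)c4cccc(C(F)(F)F)c4)c3)cc2-c2ccncc2)ccc1Cl` gives 24800 nM
- compound 2 `COc1cc(-c2nn(-c3cccc(NC(=O)Nc4ccc(Cl)c(Cl)c4)c3)cc2-c2ccncc2)ccc1Cl` gives 3140 nM
- compound 3 `O=C(Nc1cccc(-n2cc(-c3ccncc3)c(-c3ccc(Cl)c(O)c3)n2)c1)Nc1ccc(Cl)c(Cl)c1` gives 22700 nM

Compound 2 has the lowest number of the three in this assay; the other two stand beyond the scatter above it. Compound 4 `COc1cc(-c2nn(-c3cccc(NC(=O)c4ccc(Cl)c(C(F)(F)F)c4)c3)cc2-c2ccncc2)ccc1Cl` differs from compound 2 by 4-chloro-3-(trifluoromethyl)phenyl in place of (3,4-dichlorophenyl)amino on a carbonyl carbon. The step that bears on this is the one between the amide of compound 1 and the urea of compound 2, a 7.9-fold lower number from compound 1 to compound 2 (0.90 log units; beyond the scatter); compound 4 goes back to an amide, so the reverse direction is expected, with the added chlorine on the ring being the only element without a measured precedent. The step of a 7.2-fold higher number from compound 2 to compound 3 (0.86 log units; beyond the scatter) concerns a different part of the molecule and does not bear on it. Compound 4 is therefore expected to give a higher number, about a 4.8-fold higher number from compound 2 to compound 4 (0.68 log units; beyond the scatter), estimated at 15000 nM (range 5000 nM to 40000 nM).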

Compound 4, concentration lethal to 50% of the cells: > 32500 nM
Compound 4 gave a limit, no number (the forecaster's own chance of this, stated with the estimate: 10%); middle value at least 2.1-fold (0.33 log units) away from the limit.
By their numbers in this assay, from the lowest: compound 2; then compounds 3 and 1 (each within the scatter of the next). At a limit, above all of these: compound 4.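

In this assay compound 4 stands at a limit and not a number: the limit of > 32500 nM in this assay, at which 1 of the 4 values shown sits. With 4-chloro-3-(trifluoromethyl)phenyl in place of (3,4-dichlorophenyl)amino on the carbonyl carbon, the series shows an at least 10-fold higher number from compound 2 to compound 4 (1.01 log units; beyond the scatter), so the direction seen between urea and amide also holds with this chlorinated ring. Chloro in place of hydrogen on the aromatic carbon gives an at least 1.3-fold higher number from compound 1 to compound 4 (0.11 log units; that floor lies within the scatter), a floor that does not separate the two amides.

Still open, going by these compounds, is how far the true value of compound 4 lies past its limit. Also open, on these data alone, is whether a carboxylic acid or a dimethylamino group in place of that chloro would shift the number of the amide.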